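The source may hold more compounds than are shown below. What is called first, only, known or untested is meant among the compounds shown, and "the series" means these compounds.

Compound 1 `CCCOC(=O)[C@@H](N)CCC(=O)NCCSC(=O)c1ccccc1` and compound 2 `CCCCOC(=O)[C@@H](N)CCC(=O)NCCSC(=O)C(C)(C)C` have both been run in an ADME assay on liver for metabolic stability, with liver carboxylesterase 1 (Homo sapiens) as the target; a lower number here means that the compound disappears faster, a higher number that the compound lasts longer. Compound 1 gives 0.167 h, and compound 2 gives 0.167 h, so compound 1 stands level with compound 2 within the scatter. Compound 3 `CCCOC(=O)[C@@H](N)CCC(=O)NCCSC(=O)C(C)(C)C` has not yet been measured in this assay. It differs from compound 1 in one place: tert-butyl in place of phenyl on a carbonyl carbon. Compound 2 already carries the entering group and, level with compound 1 within the scatter, compound 2 sits at 0.167 h, which leaves no sign of a step beyond the scatter. Compound 3 is therefore expected to show 0.17 h, with a range from 0.08 h to 0.35 h. The step of a 1.0-fold higher number from compound 1 to compound 3 (0.01 log units; within the scatter) that this estimate implies is expected to stay within the scatter.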

Compound 3, half-life: 0.167 h
Compound 3: the middle estimate sits 1.0-fold (0.01 log units) above what was measured; the measured number falls inside the stated range.
By their numbers in this assay, from the lowest: compounds 1, 2 and 3 (each within the scatter of the next).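

In this assay, tert-butyl in place of phenyl on a carbonyl carbon gives no change at the digits printed from compound 1 to compound 3 (within the scatter) as its step, so this place now has a direct one-place comparison. Hydrogen in place of methyl on a saturated chain carbon, three bonds along the chain from an oxygen next to a carbonyl group, gives no change at the digits printed from compound 2 to compound 3 (within the scatter) as its step, so neither change moves the number beyond the scatter. On these data alone, whether a carboxylic acid at the chain end or a cyclohexyl group on the carbonyl carbon would move it stays open. Nothing available here explains why these changes leave the number level.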